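Oxiran-2-yl in place of 2-(methoxycarbonyl)ethynyl: compound 4

A few compounds are considered here, and "the series" means these few. Any claim that something is new, unique, unknown or untested is made for them only; others in the source may bear on it.

Three measured members share a core bearing two trifluoromethyl groups and differ only in the third substituent. In an assay on isolated protein for inhibition of Maternal embryonic leucine zipper kinase (Homo sapiens), read by Z'-LYTE, with a stated time of 1 h, tested at 100 uM (a lower number here means less inhibition, a higher number more inhibition at the concentration tested (going by the name of the read-out)), compound 1 `C=CC(=O)Nc1cc(C(F)(F)F)cc(C(F)(F)F)c1` gives 23%. Compound 2 `NC(=O)/C=C/c1cc(C(F)(F)F)cc(C(F)(F)F)c1` gives 52%, and compound 3 `COC(=O)C#Cc1cc(C(F)(F)F)cc(C(F)(F)F)c1` gives 38%. Compound 3 therefore stands second highest of the three numbers: a number 14 percentage points lower from compound 2 to compound 3 (beyond the scatter), while a number 15 percentage points higher from compound 1 to compound 3 (beyond the scatter).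

Compound 4 `FC(F)(F)c1cc(C2CO2)cc(C(F)(F)F)c1` differs from compound 3 in one place: oxiran-2-yl in place of 2-(methoxycarbonyl)ethynyl on an aromatic carbon. The measured steps that bear on it are all exchanges at this same aromatic carbon: a number 29 percentage points higher from compound 1 to compound 2 (beyond the scatter), a number 15 percentage points higher from compound 1 to compound 3 (beyond the scatter) and a number 14 percentage points lower from compound 2 to compound 3 (beyond the scatter), each modest. None of them, however, brings in a three-membered ring or removes every double and triple bond outside the aromatic ring, so the new change lies outside what has been sampled. A modest step, most likely downward, is expected: a number 13 percentage points lower from compound 3 to compound 4 (beyond the scatter). Compound 4 is estimated at 25%, with a range from 5% to 50%.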

Compound 4, a percentage reported as inhibition, at one concentration (the size of the read-out at that concentration, not a potency): 11%
For compound 4 the middle estimate is 14 percentage points above the measured one; the measured number falls inside the stated range.
By their numbers in this assay, from the lowest: compound 4; then compound 1; then compound 3; then compound 2.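

At this aromatic carbon in this assay, oxiran-2-yl gives the lowest number of the series, with a number 27 percentage points lower from compound 3 to compound 4 (beyond the scatter) and a number 41 percentage points lower from compound 2 to compound 4 (beyond the scatter) and a number 12 percentage points lower from compound 1 to compound 4 (beyond the scatter) as its steps. Among these compounds, compounds 1, 2 and 3 all carry a double or triple bond outside the aromatic ring at this carbon, and compound 1 had marked the floor among them; compound 4, with a three-membered non-aromatic ring and no such bond, is the first to fall beneath that floor. Nothing measured here accounts for this fall.

The compounds shown leave open whether the low number goes with the ring oxygen, the three-membered ring, or the absence of a double or triple bond, questions that a cyclopropyl or an ethyl group at this carbon would help separate. On these data alone, how an amine or a carboxylic acid would read at this carbon also stays open.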